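A few compounds are considered here, and "the series" means these few. Any claim that something is new, unique, unknown or untested is made for them only; others in the source may bear on it.

Measured compounds:
compound 1, `CCCn1c(=O)[nH]c2nc(-c3ccc(OCC(=O)NCCCCc4ccccc4)cc3)[nH]c2c1=O`: 1410 nM
compound 2, `CCCn1c(=O)[nH]c2nc(-c3ccc(OCC(=O)NCc4ccccc4)cc3)[nH]c2c1=O`: 266 nM

Among the compounds with values here, in an assay on CHO cells for displacement of a labelled ligand from adenosine receptor A3 (Homo sapiens), read by scintillation counting, with a stated time of 45 min (on this read-out higher numbers stand for weaker inhibition and lower numbers for stronger inhibition), compound 2 gives 266 nM and holds the lowest of the two numbers measured; compound 1 gives 1410 nM, and the one step between them, a 5.3-fold lower number from compound 1 to compound 2 (0.72 log units; beyond the scatter), is modest but beyond the scatter.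

Compound 3, `CCCn1c(=O)[nH]c2nc(-c3ccc(OCC(=O)NCCCc4ccccc4)cc3)[nH]c2c1=O`, has not been measured in this assay. It differs from compound 2 by phenethyl in place of phenyl on a saturated chain carbon bound to an amide-type nitrogen, so the chain between the amide-type nitrogen and the aromatic ring is lengthened, though not as far as in compound 1. Within the data shown here, the only measured step that bears on this change is a 5.3-fold lower number from compound 1 to compound 2 (0.72 log units; beyond the scatter), which shows that moving from the shorter to the longer chain raises the number. Compound 3 lies between these two cases, so a rise of less than that step is expected in this assay, with the estimate for compound 3 being a 2.1-fold higher number from compound 2 to compound 3 (0.32 log units; beyond the scatter). The inhibition constant of compound 3 is therefore estimated at 550 nM, within a range from 200 nM to 1500 nM.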

Compound 3, inhibition constant: 2990 nM
The estimate for compound 3 lay 5.4-fold (0.74 log units) below the measured number; the whole stated range lies below it.
By their numbers in this assay, from the lowest: compound 2; then compound 1; then compound 3.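

In this assay, the phenethyl group on a saturated chain carbon bound to an amide-type nitrogen costs far more than the earlier pair suggested, with an 11-fold higher number from compound 2 to compound 3 (1.05 log units; beyond the scatter), a large step for the addition of only two carbons to the chain. The response to chain length also turns out not to be steady: going on to the 3-phenylpropyl group does not raise the number further, since the phenethyl group gives a 2.1-fold higher number from compound 1 to compound 3 (0.33 log units; beyond the scatter), so the number rises from phenyl to phenethyl and then falls again at 3-phenylpropyl, which goes against any simple rise with length. Nothing available accounts for this uneven response to chain length.

Going by these compounds, whether a chain longer than 3-phenylpropyl would bring the number down further or raise it again remains open, as does whether the phenyl ring at the end of the chain matters at all. A pyridine ring, a terminal amine or a carboxylic acid at the end of these chains could show how much of the pattern depends on that ring rather than on the chain.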